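Redrawing one stereocentre: an estimate for compound 3

The source may report more compounds than this note shows. Statements on the series, on what has been measured and on what is new or still open speak of the compounds shown alone.

Of the compounds shown here, two have been measured so far in an ADME assay on Vero cells (Chlorocebus sabaeus) for cytotoxicity, read by MTT assay, with a stated time of 72 h (on this read-out higher numbers stand for lower toxicity in this test and lower numbers for higher toxicity in this test), as a test of toxicity to the cells. Compound 1 (`COc1ccccc1[C@@H](O)COC(=O)/C=C/c1ccccc1`) gives 51700 nM there, and compound 2 (`O=C(/C=C/c1ccccc1)OC[C@@H](O)c1ccccc1`) gives 39200 nM in the same test. These two values lie within the usual scatter of each other, so compound 2 cannot be told apart from compound 1 on these numbers. Compound 3 (`O=C(/C=C/c1ccccc1)OC[C@H](O)c1ccccc1`) is the next to be read against compound 2. The change is the two compounds have the same atoms and bonds and differ only in configuration as drawn: 1 of 2 stereo elements differ; a stereocentre at a saturated chain carbon is drawn S in compound 2 and R in compound 3 in that the two compounds have the same atoms and bonds, and a stereocentre at a saturated chain carbon is drawn S in compound 2 and R in compound 3. Within the data shown here, the data hold no measured pair that differs only in configuration. In this assay no step beyond the scatter is therefore expected, in either direction, and the expectation is anchored on compound 2 at 39200 nM as its nearest structure. The estimated 1.0-fold higher number from compound 2 to compound 3 (0.01 log units; within the scatter) is small. For compound 3 the expected value is 40000 nM with an estimated range from 18000 nM to 85000 nM in this test.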

Compound 3, half-maximal cytotoxic concentration: 30300 nM
Beside the measured number, compound 3's estimate is 1.3-fold (0.12 log units) above it; measured number inside the range.
By their numbers in this assay, from the lowest: compounds 3, 2 and 1 (each within the scatter of the next).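

In this assay, redrawing the stereocentre at a saturated chain carbon, S in compound 2 and R in compound 3, gives a 1.3-fold lower number from compound 2 to compound 3 (0.11 log units; within the scatter), so on this read-out the drawn configuration at this position does not separate the two compounds. Among these compounds, this is the first measured pair in which nothing but that stereocentre can account for the reading, and the comparison isolates this one position because of a single fact about the pair: the fact that compounds 2 and 3 differ only in the configuration as drawn. The other new step, which goes with hydrogen in place of methoxy on an aromatic carbon, is a 1.7-fold lower number from compound 1 to compound 3 (0.23 log units; within the scatter), so neither change moves the reading in this assay outside the usual scatter of repeated measurements.

The compounds shown leave open whether redrawing the same stereocentre in the methoxy compound, compound 1, would also stay inside the scatter. They also leave open whether a different group at these places, such as an amine in place of the hydroxyl on the chain or a carboxylic acid on the aromatic ring, would give a step beyond the scatter in this test.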